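Removing a chloro group from compound 1: expected effect on growth

This account rests on a few compounds, and the source may have more. Where it says the series, first, only, none or still open, it means among the compounds named here.

Of the compounds shown here, three have been tested in a functional assay on cells (Cancer cell lines, Homo sapiens) for cytotoxicity, with a stated time of 48 h; on this read-out lower numbers stand for stronger inhibition of growth and higher numbers for weaker inhibition of growth. Compound 1, `O=C1Nc2ccc(Cl)cc2/C1=C\c1c(Cl)n(CCCc2ccccc2)c2ccccc12`, gives 9770 nM in this assay. Compound 2, `COc1cc2c(/C=C3/C(=O)Nc4cccc(Cl)c43)c(Cl)n(Cc3cc(OC)c(OC)c(OC)c3)c2cc1C`, gives 11800 nM in this assay, and compound 3, `COc1cc2c(c(OC)c1OC)/C(=C\c1c(Cl)[nH]c3ccccc13)C(=O)N2`, gives 5370 nM in this assay. Compound 1 has the second highest of the three numbers; compound 2 is nearest to it, and the gap between them lies within the scatter of repeated measurements, while the gap to compound 3, the furthest of the three, also lies within the scatter. The three values therefore cannot be put in order.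

The untested compound 4, `O=C1Nc2ccccc2/C1=C\c1c(Cl)n(CCCc2ccccc2)c2ccccc12`, differs from compound 1 in one place: hydrogen in place of chloro on an aromatic carbon. Among the measured compounds shown here, no pair among the measured compounds shows this same change on its own, so the data give no direct guide to its size. Since the three measured values all sit within the scatter of one another despite differing in several places, the step is expected to be small, and the number for compound 4 is expected to stay close to that of compound 1, with an estimated change of a 1.2-fold higher number from compound 1 to compound 4 (0.09 log units; within the scatter). Compound 4 is thus estimated at 12000 nM, within a range from 5000 nM to 30000 nM.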

Compound 4, concentration for total growth inhibition: 67600 nM
The estimate for compound 4 lay 5.6-fold (0.75 log units) below the measured number, outside the stated range (above it).
By their numbers in this assay, from the lowest: compounds 3, 1 and 2 (each within the scatter of the next, the first and the last beyond it); then compound 4.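

In this assay, the step from hydrogen in place of chloro is a 6.9-fold higher number from compound 1 to compound 4 (0.84 log units; beyond the scatter), which is beyond the scatter. The three earlier compounds differ in several places and gave no sign that one atom could matter this much. This first readable single change shows that, at this aromatic carbon, meta to a fused ring and para to a fused ring, chloro goes with stronger inhibition of growth than hydrogen does. No measurement at hand accounts for the size of this step.

On these data alone, whether another group on this carbon, such as bromo or an amine, would match chloro or hydrogen remains open. Among the compounds shown here, it is also open whether removing this chloro group would have a similar effect on a compound with a shorter chain in place of the one in compound 1.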